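This account rests on a few compounds, and the source may have more. Where it says the series, first, only, none or still open, it means among the compounds named here.

Of the compounds shown here, three built on the shared core have been measured in a functional assay on OVCAR-3 cells (Homo sapiens) for inhibition, read by sulforhodamine B assay, with a stated time of 48 h; a higher number here means a weaker inhibitor of growth, a lower number a stronger inhibitor of growth. Compound 2 `Nc1cc(N)c2nc(-c3ccccc3)c(NCc3ccc(Cl)c(Cl)c3)nc2c1` gives 2630 nM, the lowest number of the three. Compound 3 `CCOC(=O)[C@H](CCC(=O)O)NC(=O)c1ccc(Sc2nc3cc(N)cc(N)c3nc2-c2ccccc2)cc1` gives 12300 nM and compound 1 `CCOC(=O)[C@H](CCC(=O)O)NC(=O)c1ccc(CNc2nc3cc(N)cc(N)c3nc2-c2ccccc2)cc1` gives 49000 nM; both numbers stand higher than that of compound 2, in each case beyond the scatter. Compound 4 `COc1ccc(CNc2nc3cc(N)cc(N)c3nc2-c2ccccc2)cc1` has not yet been measured in this assay. It differs from compound 2 by 4-methoxyphenyl in place of 3,4-dichlorophenyl on a saturated chain carbon bound to a nitrogen on an aromatic ring. For the measured compounds named here, no measured pair shows this change, so its effect has no precedent here. A modest step upward is expected, of a size close to the edge of the scatter. For compound 4 the expected value in this assay is 6000 nM, with a range from 2000 nM to 20000 nM. The expected step from compound 2 to compound 4 is a 2.3-fold higher number from compound 2 to compound 4 (0.36 log units; beyond the scatter).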

Compound 4, concentration for 50% growth inhibition: 2240 nM
Compound 4: the middle estimate sits 2.7-fold (0.43 log units) above what was measured; the measured number falls inside the stated range.
By their numbers in this assay, from the lowest: compounds 4 and 2 (each within the scatter of the next); then compound 3; then compound 1.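

At the saturated chain carbon bound to a nitrogen on an aromatic ring, 4-methoxyphenyl in place of 3,4-dichlorophenyl gives, in this assay, a 1.2-fold lower number from compound 2 to compound 4 (0.07 log units; within the scatter), the first step read at this position. The two benzyl groups are therefore not told apart here, although the entering group carries a hydrogen-bond acceptor and the leaving group none. No measurement at hand bears on why this substitution leaves the number within the scatter.

Still open, from the compounds shown here alone, is how an unsubstituted phenyl, a single chlorine or a pyridine ring would read at this position. A basic amine or a carboxylic acid on the benzyl ring also remains untested in the compounds shown.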